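Thioether variation on the shared core: the step to compound 4

The compounds below may be only part of what the source reports. "The series", "measured", "known", "first", "only" and "open" are said of these compounds alone.

Measured so far:
compound 1 `CCCSc1nc2nc(C)cc(N3CC[C@@H](C)[C@@H](N(C)c4ncnc5[nH]ccc45)C3)n2n1` — 51200 nM
compound 2 `Cc1cc(N2CC[C@@H](C)[C@@H](N(C)c3ncnc4[nH]ccc34)C2)n2nc(SCc3ccc(C(F)(F)F)cc3)nc2n1` — 23300 nM
compound 3 `Cc1cc(N2CC[C@@H](C)[C@@H](N(C)c3ncnc4[nH]ccc34)C2)n2nc(SCC3CC3)nc2n1` — 36500 nM

In a functional assay on BGC-823 cells (Homo sapiens) for inhibition, read by MTT assay, with a stated time of 72 h (on this read-out lower numbers stand for stronger inhibition and higher numbers for weaker inhibition), compound 3 gives 36500 nM, the second highest of the three numbers. Its nearest neighbour is compound 1: the step of a 1.4-fold lower number from compound 1 to compound 3 (0.15 log units; within the scatter) lies within the scatter. The step of a 1.6-fold higher number from compound 2 to compound 3 (0.19 log units; within the scatter) is also within the scatter, so no order among compounds 2 and 3 can be read from these numbers. Among the compounds with values here, the only step beyond the scatter in the set is a 2.2-fold lower number from compound 1 to compound 2 (0.34 log units; beyond the scatter), a modest one.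

Compound 4 `C=CCSc1nc2nc(C)cc(N3CC[C@@H](C)[C@@H](N(C)c4ncnc5[nH]ccc45)C3)n2n1` differs from compound 3 at the same place where all three measured compounds differ from one another: vinyl in place of cyclopropyl on a saturated chain carbon bound to a sulfur. Within the data shown here, the steps that bear on it are a 1.4-fold lower number from compound 1 to compound 3 (0.15 log units; within the scatter) (within the scatter) and a 2.2-fold lower number from compound 1 to compound 2 (0.34 log units; beyond the scatter) (modest, beyond the scatter); both show that the group on the saturated chain carbon bound to sulfur moves the read-out little. A vinyl in place of cyclopropyl is a smaller change than either of those, so no step beyond the scatter is expected here, in either direction. Compound 4 is therefore estimated at 40000 nM, range 18000 nM to 90000 nM, which is an expected step of a 1.1-fold higher number from compound 3 to compound 4 (0.04 log units; within the scatter).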

Compound 4, half-maximal inhibitory concentration: 40900 nM
For compound 4 the middle estimate is 1.0-fold (0.01 log units) below the measured one, within the range that was stated.
By their numbers in this assay, from the lowest: compounds 2, 3, 4 and 1 (each within the scatter of the next, the first and the last beyond it).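

In this assay, the vinyl group brings a new kind of change to the saturated chain carbon bound to a sulfur: a double bond outside aromatic rings, with no ring. All three of its steps stay within the scatter: a 1.1-fold higher number from compound 3 to compound 4 (0.05 log units; within the scatter), a 1.3-fold lower number from compound 1 to compound 4 (0.10 log units; within the scatter) and a 1.8-fold higher number from compound 2 to compound 4 (0.24 log units; within the scatter). Compound 4 therefore adds no second step beyond the scatter, so the step from compound 1 to compound 2 remains the only one, and exchanging cyclopropyl for vinyl, or ethyl for vinyl, gives no readable change at this place; no measurement bears on why the read-out responds so little here.

Still open, as far as these compounds go, is whether an amine, a carboxylic acid or a longer chain on the saturated chain carbon bound to a sulfur would give a step beyond the scatter, and larger than the modest one between compound 1 and compound 2. All four compounds share the same core and differ only at this place, so they say nothing about how changes elsewhere on that core would affect the read-out.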